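The source may hold more compounds than are shown below. What is called first, only, known or untested is meant among the compounds shown, and "the series" means these compounds.

Measured so far:
compound 1, `CCCCCc1ccc(NS(=O)(=O)c2ccc(N3CCNC3=O)cc2)cc1`: in a functional assay on MCF7 cells (Homo sapiens) for antiproliferative activity, read by sulforhodamine B assay, with a stated time of 48 h (a higher number here means a weaker inhibitor, a lower number a stronger inhibitor), compound 1 gives only a limit of the assay, > 1000 nM (the limit of > 1000 nM in this assay, at which 1 of the 3 values shown sits).
compound 2, `O=C1NCCN1c1ccc(S(=O)(=O)Nc2ccc(OC(F)F)cc2)cc1`: in this assay compound 2 gives 760 nM.
compound 3, `O=C1NCCN1c1ccc(S(=O)(=O)Nc2ccc(I)cc2)cc1`: in this assay compound 3 gives 600 nM.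

Compound 3 carries the lower of the two numbers, but a 1.3-fold lower number from compound 2 to compound 3 (0.10 log units; within the scatter), so compounds 2 and 3 are not separated. The steps from compound 1, an at least 1.3-fold lower number from compound 1 to compound 2 (0.11 log units; that floor lies within the scatter) and an at least 1.6-fold lower number from compound 1 to compound 3 (0.22 log units; that floor lies within the scatter), rest on a limit and are likewise uninformative as to size.

Next compound: compound 4, `Cc1ccc(C)c(NS(=O)(=O)c2ccc(N3CCNC3=O)cc2)c1`. The change is 2,5-dimethylphenyl in place of 4-iodophenyl on a sulfonamide nitrogen. All three measured steps vary the group on the same aryl ring that sits on the sulfonamide nitrogen, and none of them moves the number beyond the scatter; none of them involves 2,5-dimethylphenyl, so the nearest guide is that exchanges at this ring have so far been flat. The expectation for this assay is therefore no step beyond the scatter in either direction, a 1.3-fold higher number from compound 3 to compound 4 (0.10 log units; within the scatter), with the caveat that a shift back to a limit, as seen with compound 1, cannot be excluded.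

Compound 4 is estimated at 750 nM, with a range from 300 nM to 2000 nM.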

Compound 4, half-maximal inhibitory concentration: 48 nM
Compound 4: middle estimate off by 16-fold (1.19 log units), on the high side, and the stated range ends above it.
By their numbers in this assay, from the lowest: compound 4; then compounds 3 and 2 (each within the scatter of the next). At a limit, above all of these: compound 1.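

In this assay, within the data shown here, the group on the sulfonamide nitrogen is not a flat position after all: the exchange gives a 13-fold lower number from compound 3 to compound 4 (1.10 log units; beyond the scatter), the only step that lies beyond the scatter and has a measured number at both ends. Both groups are six-membered aromatic rings of carbon only, with no hydrogen-bond donors or acceptors and no net charge, so the step comes from an exchange that leaves these counted features unchanged, and compound 4 is the only compound shown with 2,5-dimethylphenyl, which means the finding rests on this single example. Nothing among the data shown accounts for the size of the step.

Still open, from the compounds shown here alone, is whether the two methyl groups are both needed, or whether a single methyl group on the aryl ring would give a similar number. Also open, going by these compounds, is how far the ring tolerates other groups in the same places, such as ethyl, methoxy, chloro or an amine, and whether any of them keeps the number of compound 4.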